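Stability series: the step from compound 3 to compound 4

The source may report more compounds than this note shows. Statements on the series, on what has been measured and on what is new or still open speak of the compounds shown alone.

Measured compounds:
Compound 1, `O=C(NCc1ccccc1Cl)N1C(=O)c2ccccc2S1(=O)=O`: in a physicochemical assay for pharmacokinetics (a higher number here means that the compound lasts longer, a lower number that the compound disappears faster), compound 1 gives > 166 h, which is a limit of the assay and not a number.
Compound 2, `O=C(NCc1ccccc1)N1C(=O)c2ccccc2S1(=O)=O`: in this assay compound 2 gives > 166 h, again a limit.
Compound 3, `Cc1ccccc1CNC(=O)N1C(=O)c2ccccc2S1(=O)=O`: in this assay compound 3 gives > 166 h, also a limit.

Compound 3 therefore stands where all three values sit: the limit of > 166 h in this assay, at which 3 of the 3 values shown sit. None of the three measured steps has a readable size, since each joins two limits: a step that the two limits leave unreadable from compound 1 to compound 2, a step that the two limits leave unreadable from compound 1 to compound 3 and a step that the two limits leave unreadable from compound 2 to compound 3. Hydrogen, chloro and methyl on the aromatic carbon all leave the value at the limit.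

Compound 4, `O=C(NCC1CCCCC1)N1C(=O)c2ccccc2S1(=O)=O`, is not yet measured. It differs from compound 3 as follows: cyclohexyl in place of 2-methylphenyl on a saturated chain carbon bound to an amide-type nitrogen. The three measured steps bear on this only indirectly; they exchange substituents on the aromatic ring, whereas here the whole 2-methylphenyl gives way to cyclohexyl. Within the data shown here, as no step shows a size, no direction can be read from them; the only pattern is that every compound so far sits at the limit. Compound 4 is expected to give 200 h, with a range from 80 h to 500 h. The expected step is a step that the limit leaves unreadable from compound 3 to compound 4, that is, none beyond the scatter, and most likely another limit.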

Compound 4, half-life: > 166 h
Compound 4 gave a limit, no number; the forecaster's own chance of this, stated with the estimate: 75%; the middle value does not contradict the limit.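

In this assay compound 4 gives > 166 h, which is a limit and not a number. The steps joining compound 4 to compound 1, compound 2 and compound 3 each link two limits and cannot be read. The compounds shown leave open how long each one actually lasts and whether any differ, with all of them at one value: the limit of > 166 h in this assay, at which 4 of the 4 values shown sit.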